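The compounds below may be only part of what the source reports. "The series", "measured", "known", "first", "only" and "open" are said of these compounds alone.

Measured in a functional assay on HT-29 cells (Homo sapiens); a higher number here means a weaker inhibitor, a lower number a stronger inhibitor:
- compound 1 `Cc1ccc2nc(N)nc(O)c2c1Sc1ccc(C(=O)N[C@H](C(=O)O)c2ccccc2)cc1`: > 20000 nM (a limit)
- compound 2 `Cc1ccc2nc(N)nc(O)c2c1Sc1ccc(C(=O)N[C@H](C(=O)O)c2cccc(O)c2)cc1`: 17000 nM
- compound 3 `Cc1ccc2nc(N)nc(O)c2c1Sc1ccc(C(=O)N[C@H](C(=O)O)c2cccc(C(=O)O)c2)cc1`: 1200 nM

Of the two values that are true numbers, compound 2 holds the higher. The nearest value is reached by a 14-fold lower number from compound 2 to compound 3 (1.15 log units; beyond the scatter). The entry for compound 1 is a limit of the assay, not a number.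

Compound 4 `COC(=O)[C@@H](NC(=O)c1ccc(Sc2c(C)ccc3nc(N)nc(O)c23)cc1)c1cccc(O)c1` turns the carboxy of compound 2 into methoxycarbonyl: methyl in place of hydrogen on an oxygen next to a carbonyl group. Among the compounds with values here, no measured step touches this group. The nearest evidence comes from changes on an aromatic carbon, and these are only indirect guides. One is an at least 1.1-fold lower number from compound 1 to compound 2 (0.07 log units; that floor lies within the scatter), whose floor stays within the scatter. The other is an at least 16-fold lower number from compound 1 to compound 3 (1.22 log units; beyond the scatter), which is large but concerns a different place in the molecule. Neither gives a size or direction for the new change, so no step beyond the scatter is expected in this assay. The expected change is a 1.1-fold lower number from compound 2 to compound 4 (0.05 log units; within the scatter). For compound 4 the estimated value is 15000 nM, with an expected range of 5000 nM to 35000 nM.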

Compound 4, half-maximal inhibitory concentration: 8400 nM
Estimate against measurement, compound 4: 1.8-fold (0.25 log units) above; low and high end bracket the measured number.
By their numbers in this assay, from the lowest: compound 3; then compound 4; then compound 2. At a limit, above all of these: compound 1.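

Within the data shown here, the first change at this position, methyl in place of hydrogen on an oxygen next to a carbonyl group, gives in this assay a 2.0-fold lower number from compound 2 to compound 4 (0.31 log units; beyond the scatter). The earlier compounds shown here differed only on an aromatic carbon, so they said nothing about the carboxy that all of them carry. With the hydroxy in place, turning carboxy into methoxycarbonyl does not raise the number, so a free carboxy here is not needed to hold the value of compound 2 in this assay.

As far as these compounds go, whether methyl on this oxygen gives a similar step on compound 3, and whether an ethyl group or a primary amide would act as methyl does here, stays open. The same change cannot be sized on compound 1, whose entry is only a limit: the limit of > 20000 nM in this assay, at which 1 of the 4 values shown sits.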